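This account rests on a few compounds, and the source may have more. Where it says the series, first, only, none or still open, it means among the compounds named here.

Compound 2 `CCCn1c(=O)c2nc(-c3cnn(Cc4cccc(Cl)c4)c3)[nH]c2n(CCC)c1=O` stands lowest of the two numbers measured in an in vitro assay on HEK293 cells for displacement of a labelled ligand from adenosine receptor A2b (Homo sapiens) (on this read-out higher numbers stand for weaker inhibition and lower numbers for stronger inhibition), giving 18 nM, while compound 1 `CCCn1c(=O)c2nc(-c3cnn(Cc4c(F)cccc4F)c3)[nH]c2n(CCC)c1=O` gives 390 nM. Compound 3 `CCCn1c(=O)c2nc(-c3cnn(Cc4ccc(F)c(C(F)(F)F)c4)c3)[nH]c2n(CCC)c1=O` carries 4-fluoro-3-(trifluoromethyl)phenyl in place of 3-chlorophenyl on a saturated chain carbon bound to an aromatic nitrogen. Among the compounds with values here, the one measured step that bears on this change is a 22-fold lower number from compound 1 to compound 2 (1.34 log units; beyond the scatter), which shows that exchanging the ring on the saturated chain carbon bound to an aromatic nitrogen can move the number strongly. That step, however, compared different rings, so it cannot fix the direction here. Compound 3 is therefore expected to give about 35 nM, within 10 nM to 120 nM. The expected step is a 1.9-fold higher number from compound 2 to compound 3 (0.29 log units; within the scatter).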

Compound 3, inhibition constant: 640 nM
Beside the measured number, compound 3's estimate is 18-fold (1.26 log units) below it; measured number outside the range, above it.
By their numbers in this assay, from the lowest: compound 2; then compounds 1 and 3 (each within the scatter of the next).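

In this assay the change to 4-fluoro-3-(trifluoromethyl)phenyl gives a 36-fold higher number from compound 2 to compound 3 (1.55 log units; beyond the scatter) and so shows that a second substituted ring at this place can also lose most of the strength of compound 2. The 2,6-difluorophenyl and 4-fluoro-3-(trifluoromethyl)phenyl rings show a 1.6-fold higher number from compound 1 to compound 3 (0.22 log units; within the scatter) and cannot be told apart, leaving 3-chlorophenyl alone at the stronger end. Nothing measured here explains this sensitivity to the ring. Still open, on these data alone, is whether the 4-fluoro group or the trifluoromethyl group drives the step from 3-chlorophenyl. Also open, as far as these compounds go, is how a ring carrying an amine or a carboxylic acid would read at this place.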